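A few compounds are considered here, and "the series" means these few. Any claim that something is new, unique, unknown or untested is made for them only; others in the source may bear on it.

Working notes on the series. For the measured compounds named here, compound 1 `COc1ccccc1Cc1cnc(CCc2ccc(-c3ccccc3C(=O)O)cc2)[nH]1` gives 163 nM in an in vitro functional assay on cells for agonist activity at Bombesin receptor subtype-3 (Mus musculus), read by luminescence and calcium flux (on this read-out higher numbers stand for an effect only at larger amounts of compound and lower numbers for an effect already at smaller amounts), the lowest of the two numbers available so far. Compound 2 `CCCCc1cnc(/C=C/c2ccc(-c3ccccc3C(=O)O)cc2)[nH]1` gives 10000 nM in this assay, a difference from compound 1 that lies beyond the scatter. Compound 3 `O=C(O)c1ccccc1-c1ccc(CCc2ncc(CCc3ccccc3)[nH]2)cc1` is not yet measured. The change from compound 1 to compound 3: benzyl in place of 2-methoxyphenyl on a saturated chain carbon bound to an aromatic carbon. Going by the values given here, no measured pair covers this change, so its direction rests on expectation alone; the step from a 1.8-fold higher number from compound 1 to compound 3 (0.26 log units; within the scatter) is expected to be small, a slight rise that stays within the scatter. Compound 3 is estimated at 300 nM, with a range from 100 nM to 1000 nM.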

Compound 3, half-maximal effective concentration: 174 nM
The estimate for compound 3 lay 1.7-fold (0.24 log units) above the measured number; the measured number falls inside the stated range.
By their numbers in this assay, from the lowest: compounds 1 and 3 (each within the scatter of the next); then compound 2.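

In this assay, benzyl in place of 2-methoxyphenyl on a saturated chain carbon bound to an aromatic carbon gives a 1.1-fold higher number from compound 1 to compound 3 (0.03 log units; within the scatter). The two groups are therefore not told apart by this read-out, although the hydrogen-bond acceptor of 2-methoxyphenyl is absent from benzyl. No supporting data bear on why this is so.

From the compounds shown here alone, whether an amine or a longer chain at this place would leave the number equally unchanged remains open. Compound 2 differs from compound 1 in more than one place, so its number cannot be assigned to any single change.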